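This account rests on a few compounds, and the source may have more. Where it says the series, first, only, none or still open, it means among the compounds named here.

Measured in an ADME assay for pharmacokinetics, at pH 7.4; a higher number here means that the compound lasts longer, a lower number that the compound disappears faster:
- compound 1 `COc1cnc(C[S+]([O-])c2nc3cc(OCC(F)(F)F)ccc3[nH]2)c(C)c1OC`: 130 h
- compound 2 `COc1cnc(C[S+]([O-])c2nc3cc(OC(F)(F)C(F)F)ccc3[nH]2)cc1OC`: 140 h

Compound 2 and compound 1 lie within the usual scatter of each other, so these two values give no order. Among the measured compounds shown here, no two measured compounds differ in one place only, which leaves the size of the next step without direct evidence.

Compound 3 `COc1cnc(C[S+]([O-])c2nc3cc(OC(F)(F)C(F)F)ccc3[nH]2)c(C)c1OC` derives from compound 2 by one change: methyl in place of hydrogen on an aromatic carbon. Compound 1 also carries this methyl, and in this assay compound 1 gives 130 h. No step beyond the scatter is therefore expected, and any small shift could go in either direction. The estimated change is a 1.2-fold lower number from compound 2 to compound 3 (0.07 log units; within the scatter). For compound 3 the estimated half-life is 120 h, with an expected range from 65 h to 220 h.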

Compound 3, half-life: 43 h
For compound 3 the middle estimate is 2.8-fold (0.45 log units) above the measured one; the measured number lies below the stated range.
By their numbers in this assay, from the lowest: compound 3; then compounds 1 and 2 (each within the scatter of the next).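

In this assay, methyl in place of hydrogen on this aromatic carbon, ortho to a methoxy group, gives a 3.3-fold lower number from compound 2 to compound 3 (0.51 log units; beyond the scatter) with 1,1,2,2-tetrafluoroethyl on the oxygen, so this position is not silent in that setting. With the methyl kept, 1,1,2,2-tetrafluoroethyl in place of 2,2,2-trifluoroethyl gives a 3.0-fold lower number from compound 1 to compound 3 (0.48 log units; beyond the scatter), so the low number of compound 3 goes with the two groups together and cannot be assigned to either one alone. No measurement at hand accounts for either step.

Still open, from the compounds shown here alone, is whether the methyl step keeps its size with 2,2,2-trifluoroethyl on the oxygen. Also open, going by these compounds, is how this assay responds to an ethyl group or a chlorine atom on this same aromatic carbon, and whether either one follows the methyl.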